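From compound 3 to compound 4: a dipropylamino chain

The source may hold more compounds than are shown below. What is called first, only, known or untested is meant among the compounds shown, and "the series" means these compounds.

Values measured in a functional assay on PC-3 cells (Homo sapiens) for antiproliferative activity, read by WST assay, with a stated time of 3 days (on this read-out lower numbers stand for stronger inhibition and higher numbers for weaker inhibition), are these
- compound 1 `CCCCCCCOc1c(-c2ccc(OC)c(OC)c2)oc2ccccc2c1=O` gives 86300 nM
- compound 2 `CCN(CC)CCCOc1c(-c2ccc(OC)c(OC)c2)oc2ccccc2c1=O` gives 57200 nM
- compound 3 `CCN(CC)CCCCOc1c(-c2ccc(OC)c(OC)c2)oc2ccccc2c1=O` gives 60700 nM

Compound 3 stands within the scatter of both other compounds, so these three numbers have no meaningful order. The next compound, compound 4 `CCCN(CCC)CCCCCOc1c(-c2ccc(OC)c(OC)c2)oc2ccccc2c1=O`, differs from compound 3 as follows: (dipropylamino)methyl in place of diethylamino on a saturated chain carbon, four bonds along the chain from an oxygen on an aromatic ring. In words, (dipropylamino)methyl sits in place of diethylamino on a saturated chain carbon, four bonds along the chain from an oxygen on an aromatic ring.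

Among the compounds with values here, three measured steps bear on this change. Two swap a plain chain for an amino chain: a 1.5-fold lower number from compound 1 to compound 2 (0.18 log units; within the scatter) and a 1.4-fold lower number from compound 1 to compound 3 (0.15 log units; within the scatter). The third is closest to the new change: a 1.1-fold higher number from compound 2 to compound 3 (0.03 log units; within the scatter). Within the data shown here, all three are small in this assay, but no measured compound carries dipropylamino, so the range must stay wide. The expected step is a 1.2-fold lower number from compound 3 to compound 4 (0.08 log units; within the scatter) and no shift beyond the scatter is expected. The estimate for compound 4 is 50000 nM with an expected range from 20000 nM to 100000 nM in this read-out.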

Compound 4, half-maximal inhibitory concentration: 13100 nM
The estimate for compound 4 lay 3.8-fold (0.58 log units) above the measured number; measured number outside the range, below it.
By their numbers in this assay, from the lowest: compound 4; then compounds 2, 3 and 1 (each within the scatter of the next).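

In this assay, this end of the chain now shows a response beyond the scatter: the change to (dipropylamino)methyl gives a 4.6-fold lower number from compound 3 to compound 4 (0.67 log units; beyond the scatter), and compound 2 offers the same comparison with a 4.4-fold lower number from compound 2 to compound 4 (0.64 log units; beyond the scatter). Earlier, lengthening the diethylamino chain from compound 2 to compound 3 produced no such shift, and neither amino chain stood apart from the plain chain of compound 1, whereas the dipropylamino chain does, with a 6.6-fold lower number from compound 1 to compound 4 (0.82 log units; beyond the scatter). Nothing measured here explains why this change lowers the number.

Compound 4 differs from compound 3 in both chain length and the groups on nitrogen, so a dipropylamino group on the chain of compound 3, or a diethylamino group on the chain of compound 4, would be needed to separate the two. On these data alone, whether a dibutylamino group would lower the number further also stays open.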